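A few compounds are considered here, and "the series" means these few. Any claim that something is new, unique, unknown or untested is made for them only; others in the source may bear on it.

Measured in an ADME assay on the whole organism (strain Sprague-Dawley) for pharmacokinetics, with Rattus norvegicus as the target, read by LC-MS; a higher number here means that a larger share of the oral dose reaches the circulation, a lower number that a smaller share of the oral dose reaches the circulation:
- compound 1 `O=c1[nH]ccn1CCOc1nn(-c2ccccc2F)c2ccc(F)cc12`: 35%
- compound 2 `O=C1NCCN1CCOc1nn(-c2ccc(F)cc2)c2ccc(F)cc12`: 54%
- compound 3 `CC(C)(C)OC(=O)N1CCN(c2cccc3c2cnn3-c2ccccc2F)C1=O`: 100%

Compound 1 gives the lowest of the three numbers. Compound 2 is nearest and compound 3 furthest, and both gaps lie beyond the scatter.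

Compound 4 `O=C(COc1nn(-c2ccccc2F)c2ccc(F)cc12)N1CCOCC1` carries (morpholin-4-yl)carbonyl on a saturated chain carbon bound to an oxygen on an aromatic ring, in place of the group with the five-membered aromatic ring in compound 1: a group of 8 heavy atoms (5 carbon, 1 nitrogen, 2 oxygen; one six-membered non-aromatic ring with 2 hetero atoms) in place of a group of 7 heavy atoms (4 carbon, 2 nitrogen, 1 oxygen; one five-membered aromatic ring with 2 hetero atoms), on a saturated chain carbon bound to an oxygen on an aromatic ring. Among the compounds with values here, no measured pair isolates this change, so the expectation is loose. As compound 1 stands lowest at 35%, a modest rise in this assay is expected, not clearly beyond the scatter. The expected step is a number 9 percentage points higher from compound 1 to compound 4 (within the scatter). For compound 4 the estimate is 44%, with an expected range of 20% to 70%.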

Compound 4, oral bioavailability: 22%
For compound 4 the middle estimate is 22 percentage points above the measured one; low and high end bracket the measured number.
By their numbers in this assay, from the lowest: compound 4; then compound 1; then compound 2; then compound 3.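

At the saturated chain carbon bound to an oxygen on an aromatic ring, (morpholin-4-yl)carbonyl in place of the group with the five-membered aromatic ring gives, in this assay, a number 13 percentage points lower from compound 1 to compound 4 (beyond the scatter). Within the data shown here, this is the only single-place comparison so far, and it shows that the number responds to the group carried at this position. Nothing measured here bears on the reason for the step.

On these data alone, whether an open-chain amine or a carboxylic acid at this place would also fall under compound 1 remains open. So does whether the step carries over to the core of compound 2.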